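A Fluoro Substitution Tested on Two Cores

The source may hold more compounds than are shown below. What is called first, only, known or untested is meant among the compounds shown, and "the series" means these compounds.

Compound 1 `Fc1cc(Cl)ccc1-c1ccc(Cn2nnc3ccccc32)cn1` gives 0.8 mL/min/g in an ADME assay on microsomes from liver (Rattus norvegicus, strain Wistar) for metabolic stability, tested at 2.5 uM; on this read-out lower numbers stand for slow clearance and higher numbers for fast clearance. Compound 2 `Fc1cc(Cl)ccc1-c1ccc(Cn2nnc3c(F)cccc32)cn1` differs from it by fluoro in place of hydrogen on an aromatic carbon and gives 0.6 mL/min/g in this assay, so that a 1.3-fold lower number from compound 1 to compound 2 (0.12 log units; within the scatter). Compound 3 `Brc1cccc2c1nnn2Cc1ccccc1` gives 2 mL/min/g in this assay, the highest of the three numbers; the difference between its core and the core of compound 1 is not broken down here. Compound 4 `Fc1ccccc1Cn1nnc2c(Br)cccc21` carries the same kind of change, (fluoro in place of hydrogen on an aromatic carbon), though the place differs: in compound 2 the carbon is part of a fused or bridged system of two rings, ortho to a fused ring and meta to a fused ring, whereas in compound 4 it is ortho to a large group. The expected step in this assay is a 1.2-fold lower number from compound 3 to compound 4 (0.07 log units; within the scatter). This expectation rests on the earlier step of a 1.3-fold lower number from compound 1 to compound 2 (0.12 log units; within the scatter). Compound 4 is therefore expected to give 1.7 mL/min/g, between 0.9 mL/min/g and 3.5 mL/min/g.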

Compound 4, intrinsic clearance in a liver preparation (reported as CLH), per the amount of preparation that the assay uses: 1.8 mL/min/g
The estimate for compound 4 lay 1.1-fold (0.02 log units) below the measured number, within the range that was stated.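

Fluoro in place of hydrogen on an aromatic carbon gives a 1.1-fold lower number from compound 3 to compound 4 (0.05 log units; within the scatter) in this assay and so stays within the scatter here, as it did on the core of compound 1. Within the data shown here, this shows only that the change left the read-out within the scatter on these two cores, with the fluoro at a different place on each; it does not show that this would hold on another core, and it does not separate the effect of the core from that of the place. Set side by side, the two steps agree: the same change on two cores in this assay, a 1.3-fold lower number (0.12 log units; within the scatter) from compound 1 to compound 2 and a 1.1-fold lower number (0.05 log units; within the scatter) from compound 3 to compound 4, 1.2-fold (0.08 log units) apart, within the scatter of two such steps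

The compounds shown leave open whether chloro, a methoxy group or an amine on the same aromatic carbon would move the read-out beyond the scatter. Also open, on these data alone, is how fluoro would read at other places on these two cores.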